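Shortening the chain while restoring the acid from compound 2

This account rests on a few compounds, and the source may have more. Where it says the series, first, only, none or still open, it means among the compounds named here.

Compound 2 `CNC(=O)CCCCCc1cccc2cncn12` gives 270 nM in an assay for inhibition of Thromboxane-A synthase (Homo sapiens) (on this read-out higher numbers stand for weaker inhibition and lower numbers for stronger inhibition), the second highest of the three numbers recorded. Compound 1 `O=C(O)CCCCCCc1cccc2cncn12` gives 5.2 nM, and compound 3 `Cc1ncc2cccc(CCCCCC(=O)O)n12` gives 25000 nM. Compound 4 `O=C(O)CCCCc1cccc2cncn12` differs from compound 2 by carboxy in place of (methylcarbamoyl)methyl on a saturated chain carbon, four bonds along the chain from an aromatic carbon. Among the measured compounds shown here, the one measured step that bears on this change is a 52-fold higher number from compound 1 to compound 2 (1.72 log units; beyond the scatter), where the carboxylic acid gave the far lower number; compound 4 returns to an acid, but on a shorter chain, and no measured pair shows what two fewer chain carbons do on their own, which widens the uncertainty. A step of roughly the reverse size is therefore expected, a 9.0-fold lower number from compound 2 to compound 4 (0.95 log units; beyond the scatter). For compound 4 an estimated 30 nM is expected, between 5 nM and 300 nM.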

Compound 4, half-maximal inhibitory concentration: 41 nM
For compound 4 the middle estimate is 1.4-fold (0.14 log units) below the measured one, within the range that was stated.
By their numbers in this assay, from the lowest: compound 1; then compound 4; then compound 2; then compound 3.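

In this assay the carboxy end on the shorter chain brings back part of what the methylcarbamoyl end gave up, with a 6.6-fold lower number from compound 2 to compound 4 (0.82 log units; beyond the scatter) in the comparison of those two ends, but the acid series itself is sensitive to length at this place, with a 7.9-fold higher number from compound 1 to compound 4 (0.90 log units; beyond the scatter) on going from the longer acid to the shorter one. Acid alone therefore does not set the number; chain length also moves it. No evidence on hand accounts for either step.

The step between the methylcarbamoyl compound and the shorter acid still mixes end group with chain length, since a methylcarbamoyl end on the shorter chain is not among the compounds shown. On these data alone, whether a carboxylic acid on a longer chain than that of compound 1 lowers the number further also stays open.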